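The compounds below may be only part of what the source reports. "The series", "measured", "known", "first", "only" and "open" are said of these compounds alone.

Measured compounds and values:

compound 1 `CCN(CC)C(=O)C1=C(C)NC(=O)NC1c1ccco1`: 11%
compound 2 `CCC(CC)OC(=O)C1=C(C)NC(=O)NC1c1ccco1`: 2%

Both numbers come from an assay on membranes from CHO cells for displacement of a labelled ligand from adenosine receptor A1 (Homo sapiens), read by scintillation counting, with a stated time of 60 min, tested at 1 uM (on this read-out lower numbers stand for less inhibition and higher numbers for more inhibition at the one concentration tested (going by the name of the read-out)), and both sit near the bottom of the read-out. Compound 2 gives 2%, the lowest of the two numbers, and its nearest neighbour is compound 1, whose value lies within the scatter of it. Within the data shown here, the one step between the two, a number 9 percentage points lower from compound 1 to compound 2 (within the scatter), with (pentan-3-yl)oxy in place of diethylamino on a carbonyl carbon, is within the scatter and so shows no real effect of the ester for the amide.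

Compound 3 `CC1=C(C(=O)OC2CCCC2)C(c2ccco2)NC(=O)N1` differs from compound 2 only in the change (cyclopentyl in place of pentan-3-yl on an oxygen next to a carbonyl group), that is cyclopentyl in place of pentan-3-yl on an oxygen next to a carbonyl group. Among the measured compounds shown here, no measured step touches this group, so the expectation rests on the two values alone: with compound 1 and compound 2 both low and their step within the scatter, the step of a number 2 percentage points higher from compound 2 to compound 3 (within the scatter) in this assay is expected to stay within the scatter as well. Compound 3 is therefore estimated at 4%, with a range from -5% to 13%.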

Compound 3, a percentage reported as inhibition, at one concentration (the size of the read-out at that concentration, not a potency): 1%
Estimate against measurement, compound 3: 3 percentage points above, and the stated range covers the measured number.
By their numbers in this assay, from the lowest: compounds 3, 2 and 1 (each within the scatter of the next).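

In this assay, cyclopentyl in place of pentan-3-yl on an oxygen next to a carbonyl group gives a number 1 percentage points lower from compound 2 to compound 3 (within the scatter), so at this position a ring of carbon only and an open chain, each with 5 carbon atoms, cannot be told apart. The comparison with the amide now rests on a second ester, and a number 10 percentage points lower from compound 1 to compound 3 (within the scatter) reads the same way as the earlier step from the diethylamino compound, so neither ester separates from compound 1 in this series. No supporting measurement is available that could account for these three compounds reading alike.

All three numbers lie near the bottom of the read-out at the single concentration tested, so they give no sign of which features of the group on this carbonyl carbon matter, if any do. On these data alone, whether a longer chain, a benzyl ester, an amine or a carboxylic acid at this place would lift the number clear of the scatter stays open, as does any effect of changes elsewhere on the shared core.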